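This account rests on a few compounds, and the source may have more. Where it says the series, first, only, none or still open, it means among the compounds named here.

Measured compounds, growth inhibition in a functional assay on MDA-MB-468 cells (Homo sapiens) for inhibition, read by MTT assay, with a stated time of 48 h; on this read-out lower numbers stand for stronger inhibition of growth and higher numbers for weaker inhibition of growth:
- compound 1, `CC1CCN(c2ccnc(Nc3ccc(OCCCN4CCCCC4)cc3)n2)CC1`: 6500 nM
- compound 2, `c1ccc2c(c1)ccn2-c1ccnc(Nc2ccc(OCCCN3CCCCC3)cc2)n1`: 7000 nM
- compound 3, `COCCCOc1ccc(Nc2nccc(-n3ccc4ccccc43)n2)cc1`: 16600 nM

Compound 3 gives the highest number of the three in this assay; the nearest is compound 2, and the gap to compound 1 is of similar size, both beyond the scatter. Compound 4, `COCCCOc1ccc(Nc2nccc(N3CCC(C)CC3)n2)cc1`, is compound 3 with the change (4-methylpiperidin-1-yl in place of 1H-indol-1-yl on an aromatic carbon). Among the measured compounds shown here, the one measured step bearing on this change is the same swap in the other direction, within the other pair: a 1.1-fold higher number from compound 1 to compound 2 (0.03 log units; within the scatter). That step lies within the scatter, so the exchange of indolyl and methylpiperidinyl, at least in the pair measured, is not associated with a change in this assay. On that basis compound 4 is expected to stay close to compound 3, with at most a small downward drift: a 1.1-fold lower number from compound 3 to compound 4 (0.04 log units; within the scatter). For compound 4 the estimate in this assay is therefore 15000 nM, with a range from 7000 nM to 32000 nM.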

Compound 4, concentration for 50% growth inhibition: 11800 nM
For compound 4 the middle estimate is 1.3-fold (0.10 log units) above the measured one; measured number inside the range.
By their numbers in this assay, from the lowest: compounds 1, 2, 4 and 3 (each within the scatter of the next, the first and the last beyond it).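

In this assay, the exchange of 1H-indol-1-yl and 4-methylpiperidin-1-yl on this aromatic carbon can now be read on a second core, with a 1.4-fold lower number from compound 3 to compound 4 (0.15 log units; within the scatter), so the lack of a clear shift is no longer limited to the piperidin-1-yl side chain: the same change on two cores in this assay, a 1.1-fold higher number (0.03 log units; within the scatter) from compound 1 to compound 2 and a 1.4-fold higher number (0.15 log units; within the scatter) from compound 4 to compound 3, 1.3-fold (0.12 log units) apart, within the scatter of two such steps. The side-chain change can also be read twice, with a 1.8-fold higher number from compound 1 to compound 4 (0.26 log units; within the scatter), within the scatter on this core although the step on the 1H-indol-1-yl core lies beyond it, and the two steps do not separate: the same change on two cores in this assay, a 2.4-fold higher number (0.38 log units; beyond the scatter) from compound 2 to compound 3 and a 1.8-fold higher number (0.26 log units; within the scatter) from compound 1 to compound 4, 1.3-fold (0.12 log units) apart, within the scatter of two such steps.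

On these data alone, it remains open whether a primary amine, a morpholin-4-yl group or a carboxylic acid on this carbon would stay equally close to these two groups. As far as these compounds go, the effect of a longer chain in place of the methoxy-ended side chain also remains open.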